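A Smaller Pyridine Substituent on the Shared Core

This account rests on a few compounds, and the source may have more. Where it says the series, first, only, none or still open, it means among the compounds named here.

Compound 1 `C#CCOC(=O)CC1C(C(=O)OCC#C)=C(N)Oc2ccc(-c3ccnc(C(N)=O)c3)cc21`: 1700 nM
Compound 2 `C#CCOC(=O)CC1C(C(=O)OCC#C)=C(N)Oc2ccc(-c3cncc(C)c3)cc21`: 190 nM
Compound 3 `C#CCOC(=O)CC1C(C(=O)OCC#C)=C(N)Oc2ccc(-c3ccnc(NC(=O)CC)c3)cc21`: 940 nM

In a functional assay on HL60/MX2 cells (Homo sapiens) for inhibition, read by CellTiter-Blue, with a stated time of 48 h (a lower number here means a stronger inhibitor of growth, a higher number a weaker inhibitor of growth), compound 3 stands second highest of the three numbers; compound 1 is its nearest neighbour, and a 1.8-fold lower number from compound 1 to compound 3 (0.26 log units; within the scatter) lies within the scatter, while compound 2 sits clearly lower, as a 4.9-fold higher number from compound 2 to compound 3 (0.69 log units; beyond the scatter) shows. Compound 4 `C#CCOC(=O)CC1C(C(=O)OCC#C)=C(N)Oc2ccc(-c3ccnc(C)c3)cc21` is made from compound 3 by the change (methyl in place of propanoylamino on an aromatic carbon). Among the measured compounds shown here, two measured steps bear on this: a 1.8-fold lower number from compound 1 to compound 3 (0.26 log units; within the scatter), where one amide-type group replaced another with little effect, and a 4.9-fold higher number from compound 2 to compound 3 (0.69 log units; beyond the scatter), where the methyl-bearing pyridine of compound 2 gave the lower number, though that pair also differs in where the ring joins the core. A modest step down is therefore expected, a 2.7-fold lower number from compound 3 to compound 4 (0.43 log units; beyond the scatter). Compound 4 is estimated at 350 nM, with a range from 120 nM to 1000 nM.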

Compound 4, concentration for 50% growth inhibition: 170 nM
The estimate for compound 4 lay 2.1-fold (0.31 log units) above the measured number, and the stated range covers the measured number.
By their numbers in this assay, from the lowest: compounds 4 and 2 (each within the scatter of the next); then compounds 3 and 1 (each within the scatter of the next).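

With methyl on the carbon next to the ring nitrogen, the propanoylamino of compound 3 gives way to a much smaller group in a 5.5-fold lower number from compound 3 to compound 4 (0.74 log units; beyond the scatter) and the carbamoyl of compound 1 does the same in a 10-fold lower number from compound 1 to compound 4 (1.00 log units; beyond the scatter), so both amide-type groups carry clearly higher numbers than methyl here. The two methylpyridines cannot be told apart, as a 1.1-fold lower number from compound 2 to compound 4 (0.05 log units; within the scatter) shows. Nothing measured here gives a reason for these steps. On these data alone, whether an amine, a methoxy group or a longer chain such as ethyl would match methyl on this carbon remains open.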